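The compounds below may be only part of what the source reports. "The series", "measured", "known", "first", "only" and "open" are said of these compounds alone.

Compound 1 `COc1cc(-c2ccnc3cc(-c4c[nH]c5ccccc45)nn23)cc(OC)c1OC` carries a 1H-indol-3-yl group on the shared core and gives 29 nM in a functional assay on A549 cells (Homo sapiens) for inhibition, read by CCK-8 assay, with a stated time of 48 h (on this read-out lower numbers stand for stronger inhibition and higher numbers for weaker inhibition), the lowest of the two numbers reported; its nearest neighbour is compound 3, whose number is higher by a 5.9-fold higher number from compound 1 to compound 3 (0.77 log units; beyond the scatter). Compound 3 `COc1cc(-c2ccnc3cc(-c4ccc5cc[nH]c5c4)nn23)cc(OC)c1OC` bears a 1H-indol-6-yl group in that place and gives 170 nM in this assay. Compound 2 `COc1cc(-c2ccnc3cc(-c4cccc(C#N)c4)nn23)cc(OC)c1OC`, with a 3-cyanophenyl group there, reaches only the limit of this assay, > 10000 nM, which is a limit and not a number, as the limit of > 10000 nM in this assay, at which 1 of the 3 values shown sits, records. From compound 1 to compound 2 the step is an at least 340-fold higher number from compound 1 to compound 2 (2.53 log units; beyond the scatter), and from compound 2 to compound 3 it is an at least 58-fold lower number from compound 2 to compound 3 (1.76 log units; beyond the scatter).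

Compound 4 `COc1cc(-c2ccnc3cc(-c4ccc(N(C)C)cc4)nn23)cc(OC)c1OC` is not yet measured. It differs from compound 1 thus: 4-(dimethylamino)phenyl in place of 1H-indol-3-yl on an aromatic carbon. Both measured steps away from 1H-indol-3-yl raised the number, the move to a single six-membered ring most sharply, so a weakening beyond the scatter is expected, of about a 34-fold higher number from compound 1 to compound 4 (1.54 log units; beyond the scatter). Compound 4 is therefore estimated at 1000 nM in this assay, within 150 nM to 8000 nM.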

Compound 4, half-maximal inhibitory concentration: 1100 nM
Compound 4: the middle estimate sits 1.1-fold (0.04 log units) below what was measured; low and high end bracket the measured number.
By their numbers in this assay, from the lowest: compound 1; then compound 3; then compound 4. At a limit, above all of these: compound 2.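

A single six-membered ring of carbon only does not by itself end inhibition at this position in this assay: with 4-(dimethylamino)phenyl in place of 3-cyanophenyl, the step is an at least 9.0-fold lower number from compound 2 to compound 4 (0.95 log units; beyond the scatter). Compound 2 remains a limit and not a number: the limit of > 10000 nM in this assay, at which 1 of the 4 values shown sits. The two indole compounds still give the lower numbers, with a 38-fold higher number from compound 1 to compound 4 (1.58 log units; beyond the scatter) and a 6.5-fold higher number from compound 3 to compound 4 (0.81 log units; beyond the scatter), so among these four compounds both indolyl groups stand ahead of both single-ring groups, and none goes against that order.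

Compound 4 loses the hydrogen-bond donor and the five-membered ring together, and the compounds shown cannot separate these two changes. Also open, from the compounds shown here alone, is how an indol-3-yl group with a methyl on its ring nitrogen, or a phenyl ring carrying a primary amine, would behave here.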